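Microsomal stability notes: methyl for isopropyl on the core

The source may hold more compounds than are shown below. What is called first, only, known or untested is meant among the compounds shown, and "the series" means these compounds.

Measured so far in an in vitro ADME assay on microsomes (Mus musculus) for metabolic stability; a lower number here means that the compound disappears faster, a higher number that the compound lasts longer:
Compound 1 `CNC(=O)Nc1ccc(-c2nc(N3CC4CCC(C3)O4)c3cnn(C(C)C)c3n2)cc1` gives > 0.5 h, a limit of the assay.
Compound 2 `O=C(Nc1ccc(-c2nc(N3CC4CCC(C3)O4)c3cnn(C4CCC5(CC4)OCCO5)c3n2)cc1)Nc1cccnc1` gives > 0.5 h, a limit of the assay.
Compound 3 `O=C(Nc1ccncc1)Nc1ccc(-c2nc(N3CC4CCC(C3)O4)c3cnn(C4CCC5(CC4)OCCO5)c3n2)cc1` gives > 0.5 h, a limit of the assay.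

Compound 1 therefore stands at the limit in this assay, as do compound 2 and compound 3 (the limit of > 0.5 h in this assay, at which 3 of the 3 values shown sit). Among the measured compounds shown here, the one measured step, a step that the two limits leave unreadable from compound 2 to compound 3, cannot be read. Compound 4 `CNC(=O)Nc1ccc(-c2nc(N3CC4CCC(C3)O4)c3cnn(C)c3n2)cc1` differs from compound 1 by methyl in place of isopropyl on an aromatic nitrogen. For the measured compounds named here, no measured step bears on this change, and none of the three values gives a number to move from. The expected step in this assay is a step that the limit leaves unreadable from compound 1 to compound 4, that is, nothing beyond the scatter, with compound 4 expected to be reported again as a limit. The estimate for compound 4 is 0.6 h, ranging from 0.2 h to 2 h.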

Compound 4, half-life: > 0.5 h
Compound 4 was reported as a limit; the forecaster's own chance of this, stated with the estimate: 65%; the middle value lies beyond the limit too.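

No step can be read between compound 1 and compound 4 in this assay, as both are reported only as limits: the limit of > 0.5 h in this assay, at which 4 of the 4 values shown sit.

The compounds shown leave open how far any of them lies beyond that limit, and whether methyl and isopropyl differ at all.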